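This account rests on a few compounds, and the source may have more. Where it says the series, first, only, none or still open, it means among the compounds named here.

Measured compounds in a functional assay on C6 cells (Rattus norvegicus) for cytotoxicity, read by MTT assay, with a stated time of 24 h; a higher number here means a weaker inhibitor, a lower number a stronger inhibitor:
Compound 1 `N#Cc1ccc(-c2cs/c(=N/NC(=O)CSc3ncccn3)n2-c2ccccc2)cc1` gives "not determined" (no result reported).
Compound 2 `Cn1cnnc1SCC(=O)N/N=c1/scc(-c2ccc(C#N)cc2)n1-c1ccccc1` gives > 200 ug/mL, which is a limit of this assay rather than a number.
Compound 3 `Cn1nnnc1SCC(=O)N/N=c1/scc(-c2ccc(C#N)cc2)n1-c1ccccc1` gives 23.3 ug/mL.

Compound 1 therefore stands nowhere on the numbers shown: no result was reported for it. Compound 4 `COc1ccc(-c2cs/c(=N/NC(=O)CSc3ncccn3)n2-c2ccccc2)cc1` differs from compound 1 by methoxy in place of cyano on an aromatic carbon. Among the measured compounds shown here, the only measured step, an at least 8.5-fold lower number from compound 2 to compound 3 (0.93 log units; beyond the scatter), concerns the heterocycle on the sulfur and not the group on the six-membered aromatic ring of carbon only, so it does not bear on this change; one of its ends is merely (the limit of > 200 ug/mL in this assay, at which 1 of the 3 values shown sits). For the measured compounds named here, with no step touching methoxy in place of cyano and no number for compound 1, no direction of change can be expected. Compound 4 is estimated at 90 ug/mL, in a range from 20 ug/mL to 200 ug/mL, and a limit alone may well be reported.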

Compound 4, half-maximal inhibitory concentration: 102 ug/mL
Beside the measured number, compound 4's estimate is 1.1-fold (0.05 log units) below it; measured number inside the range.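

Among the compounds shown here, compound 1 gives "not determined" (no result reported) and so no step to compound 4 can be read. The compounds shown leave open how 4-methoxyphenyl in place of 4-cyanophenyl changes the number, and nothing shown accounts for the value of compound 4.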